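The source may report more compounds than this note shows. Statements on the series, on what has been measured and on what is new or still open speak of the compounds shown alone.

Measured so far:
- compound 1, `CC(C(=O)NCc1ccc(C(C)(C)C)nc1N1CCCC1)c1ccc(NS(C)(=O)=O)c(F)c1`: 1.2 nM
- compound 2, `CCCCCCOc1nc(C(C)(C)C)ccc1CNC(=O)C(C)c1ccc(NS(C)(=O)=O)c(F)c1`: 2.7 nM
- compound 3, `CCOCCOc1nc(C(C)(C)C)ccc1CNC(=O)C(C)c1ccc(NS(C)(=O)=O)c(F)c1`: 23.9 nM

These three compounds share one core and differ only in the group on an aromatic carbon of the ring that carries the tert-butyl group. In an assay on cells for antagonist activity at transient receptor potential cation channel subfamily V member 1 (Homo sapiens), read by FLIPR and calcium flux, with a stated time of 6 min (on this read-out lower numbers stand for stronger inhibition and higher numbers for weaker inhibition), compound 3 stands highest of the three numbers, meaning it is the weakest inhibitor shown: the step of an 8.9-fold higher number from compound 2 to compound 3 (0.95 log units; beyond the scatter) and the step of a 20-fold higher number from compound 1 to compound 3 (1.30 log units; beyond the scatter) both lie beyond the scatter.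

Compound 4, `CCCCSc1nc(C(C)(C)C)ccc1CNC(=O)C(C)c1ccc(NS(C)(=O)=O)c(F)c1`, has not been measured. It differs from compound 3 in one place: butylsulfanyl in place of 2-ethoxyethoxy on an aromatic carbon.

Among the compounds with values here, two measured steps bear on this change. The step of an 8.9-fold higher number from compound 2 to compound 3 (0.95 log units; beyond the scatter) shows that swapping butyl for ethoxy within the side chain raised the number markedly, so returning to an all-carbon butyl chain, now attached through sulfur, may reverse part of that loss. The step of a 2.3-fold higher number from compound 1 to compound 2 (0.35 log units; beyond the scatter) shows that a hexyloxy chain still sits close to the strongest compound. The number for compound 4 is therefore expected to fall, as a 5.3-fold lower number from compound 3 to compound 4 (0.73 log units; beyond the scatter) expresses. The estimate for compound 4 in this assay is 4.5 nM, with a range from 1.5 nM to 14 nM.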

Compound 4, inhibition constant: 3.2 nM
Compound 4: middle estimate off by 1.4-fold (0.15 log units), on the high side; low and high end bracket the measured number.
By their numbers in this assay, from the lowest: compound 1; then compounds 2 and 4 (each within the scatter of the next); then compound 3.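

Butylsulfanyl on this aromatic carbon, next to the ring nitrogen, recovers most of the ground lost with 2-ethoxyethoxy, giving a 7.5-fold lower number from compound 3 to compound 4 (0.87 log units; beyond the scatter) in this assay and showing that the atom joining the chain to the ring need not be oxygen. The chain can also change in length along with that joining atom without a clear shift, since swapping hexyloxy for butylsulfanyl gives only a 1.2-fold higher number from compound 2 to compound 4 (0.07 log units; within the scatter) in this comparison. Even so, butylsulfanyl does not match the pyrrolidin-1-yl group, with a 2.7-fold higher number from compound 1 to compound 4 (0.43 log units; beyond the scatter) on the same read-out.

The compounds shown leave open whether a longer sulfur-linked chain such as hexylsulfanyl, a shorter one such as methylsulfanyl, or an open-chain amine such as diethylamino would hold this level. Nothing measured here accounts for the differences among these groups.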